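The source may report more compounds than this note shows. Statements on the series, on what has been measured and on what is new or still open speak of the compounds shown alone.

Measured so far in a functional assay on MDA-MB-231 cells (Homo sapiens) for inhibition, read by MTT assay, with a stated time of 72 h; a lower number here means a stronger inhibitor, a higher number a weaker inhibitor:

- compound 1, `O=C(CSc1nc(Nc2ccccc2)c2ccccc2n1)Nc1cccc(Cl)c1`, gives 16500 nM
- compound 2, `O=C(CSc1nc(Nc2ccccc2)c2ccccc2n1)Nc1cccc(Br)c1`, gives 17500 nM
- compound 3, `COc1cccc(NC(=O)CSc2nc(Nc3ccccc3)c3ccccc3n2)c1`, gives 21700 nM

Compound 3 has the highest of the three numbers, but its gaps to compound 2 and to compound 1 both lie within the scatter, so the three compounds are not separated by this assay.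

The next compound, compound 4, `O=C(CSc1nc(Nc2ccccc2)c2ccccc2n1)Nc1ccc(Cl)cc1Cl`, differs from compound 3 by 2,4-dichlorophenyl in place of 3-methoxyphenyl on an amide-type nitrogen. The three measured steps are the ones that bear on it: a 1.1-fold higher number from compound 1 to compound 2 (0.03 log units; within the scatter), a 1.3-fold higher number from compound 1 to compound 3 (0.12 log units; within the scatter) and a 1.2-fold higher number from compound 2 to compound 3 (0.09 log units; within the scatter). Each exchanges one substituent for another on the same aromatic ring and each stays within the scatter. Going by the values given here, the change to compound 4 is of the same kind but larger, replacing one group with two, and no measured step covers such a double substitution. With every single swap on this ring having left the number unchanged, the expectation for compound 4 is a step of a 1.3-fold lower number from compound 3 to compound 4 (0.11 log units; within the scatter), no movement beyond the scatter, with the wider range reflecting the untested size of the change. Compound 4 is therefore estimated at 17000 nM in this assay, within 7000 nM to 40000 nM.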

Compound 4, half-maximal inhibitory concentration: 19400 nM
Compound 4: the middle estimate sits 1.1-fold (0.06 log units) below what was measured; low and high end bracket the measured number.
By their numbers in this assay, from the lowest: compounds 1, 2, 4 and 3 (each within the scatter of the next).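

Replacing the single-substituent aryl groups on the amide-type nitrogen with 2,4-dichlorophenyl does not separate the new compound from any of the earlier three in this assay: a 1.1-fold lower number from compound 3 to compound 4 (0.05 log units; within the scatter) and a 1.1-fold higher number from compound 2 to compound 4 (0.04 log units; within the scatter) and a 1.2-fold higher number from compound 1 to compound 4 (0.07 log units; within the scatter). The earlier steps shown here covered only exchanges among 3-chlorophenyl, 3-bromophenyl and 3-methoxyphenyl, whereas this result extends the flat picture at this position to an aryl group carrying two chlorines in the 2,4-pattern. No measurement is available that would account for this lack of separation.

All four compounds keep a substituted phenyl on the amide-type nitrogen and the same shared core. Going by these compounds, it remains open whether an amine, a carboxylic acid or a longer chain at this position would move the number beyond the scatter, and whether a change elsewhere on the core would do so.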